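Moving Substituents on a Shared Core

The source may hold more compounds than are shown below. What is called first, only, known or untested is meant among the compounds shown, and "the series" means these compounds.

Measured compounds:
compound 1, `Oc1ccc(-c2cc(-c3ccccc3C(F)(F)F)cc(-c3ccccc3O)n2)cc1`: 7180 nM
compound 2, `Oc1ccc(-c2cc(-c3cccc(C(F)(F)F)c3)cc(-c3ccccc3O)n2)cc1`: > 50000 nM
compound 3, `Oc1ccc(-c2cc(-c3ccccc3C(F)(F)F)cc(-c3ccc(O)cc3)n2)cc1`: > 50000 nM

In a functional assay on T47D cells (Homo sapiens) for inhibition (a lower number here means a stronger inhibitor, a higher number a weaker inhibitor), compound 1 gives 7180 nM. For compound 2 the value > 50000 nM is a limit of the assay, not a number. For compound 3 the value > 50000 nM is likewise a limit. Both sit at the limit of > 50000 nM in this assay, at which 2 of the 3 values shown sit. The change from compound 1 to compound 2 is 3-(trifluoromethyl)phenyl in place of 2-(trifluoromethyl)phenyl on an aromatic carbon, and it gave an at least 6.9-fold higher number from compound 1 to compound 2 (0.84 log units; beyond the scatter). The two cores of compound 1 and compound 3 differ by 4-hydroxyphenyl in place of 2-hydroxyphenyl on an aromatic carbon, a change that gave an at least 6.9-fold higher number from compound 1 to compound 3 (0.84 log units; beyond the scatter).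

Compound 4, `Oc1ccc(-c2cc(-c3cccc(C(F)(F)F)c3)cc(-c3ccc(O)cc3)n2)cc1`, has not yet been measured in this assay. It differs from compound 3 by 3-(trifluoromethyl)phenyl in place of 2-(trifluoromethyl)phenyl on an aromatic carbon. For the measured compounds named here, this is the same kind of change as the one from compound 1 to compound 2, but the surroundings differ: in compound 1 the place is meta to a 2-hydroxyphenyl group and meta to a 4-hydroxyphenyl group, whereas in compound 3 it is meta to two 4-hydroxyphenyl groups.

Compound 3 already sits at a limit, and the same kind of change raised the number in an at least 6.9-fold higher number from compound 1 to compound 2 (0.84 log units; beyond the scatter). The expected step from compound 3 to compound 4 is therefore a step that the limit leaves unreadable from compound 3 to compound 4, set beside that earlier step. Compound 4 is expected to give about 120000 nM in this assay. Its range is estimated between 40000 nM and 600000 nM, with a reported limit rather than a number being the likeliest outcome.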

Compound 4, half-maximal inhibitory concentration: > 50000 nM
Compound 4: a limit, no number; the forecaster's own chance of this, stated with the estimate: 85%; the middle value is on the limit's open side.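

In this assay compound 4 gives > 50000 nM, which is a limit and not a number. The steps to compound 4 from compound 3 and from compound 2 therefore cannot be read, as all three compounds sit at the same limit: the limit of > 50000 nM in this assay, at which 3 of the 4 values shown sit.

The compounds shown leave open how compound 2, compound 3 and compound 4 rank against one another in this assay.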